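Vinyl for ethyl on the aryl oxygen: expected maximal response

The source may hold more compounds than are shown below. What is called first, only, known or untested is meant among the compounds shown, and "the series" means these compounds.

Of the compounds shown here, two carry a number so far. Compound 1 `CCOc1ccccc1OC(C)C1=NCCN1` stands lowest of the two in an assay on CHO cells with Alpha-2B adrenergic receptor (Homo sapiens) as the target; on this read-out higher numbers stand for larger maximal responses and lower numbers for smaller maximal responses: compound 1 gives 0.5. Compound 2 `CC(Oc1ccccc1OC1CC1)C1=NCCN1`, which differs from it only by cyclopropyl in place of ethyl on an oxygen on an aromatic ring, reaches 0.6 in this assay; the step a number 0.10 higher from compound 1 to compound 2 (within the scatter) lies within the scatter, so the two numbers are not distinguished.

Compound 3 `C=COc1ccccc1OC(C)C1=NCCN1` has not yet been measured. It differs from compound 1 as follows: vinyl in place of ethyl on an oxygen on an aromatic ring. Among the measured compounds shown here, the only measured step that bears on this change is a number 0.10 higher from compound 1 to compound 2 (within the scatter), where a different group replaced the same ethyl on the same oxygen without moving the number beyond the scatter. A second exchange of the ethyl at that oxygen is therefore expected to leave the maximal response in this assay about where it is, with no step beyond the scatter; the expected step is no change at the digits printed from compound 1 to compound 3 (within the scatter). For compound 3 the estimate in this assay is 0.5, with a range from 0.35 to 0.7.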

Compound 3, intrinsic activity: the largest response reached, as a fraction of the reference agonist's: 0.45
For compound 3 the middle estimate is 0.050 above the measured one; the range from low to high includes it.
By their numbers in this assay, from the lowest: compounds 3, 1 and 2 (each within the scatter of the next, the first and the last beyond it).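

In this assay, vinyl in place of ethyl on an oxygen on an aromatic ring gives a number 0.050 lower from compound 1 to compound 3 (within the scatter), so the added double bond outside aromatic rings leaves the number indistinguishable from that of the ethyl group. Among the compounds shown here, the exchange between the two replacement groups is what separates numbers for the first time: vinyl in place of cyclopropyl gives a number 0.15 lower from compound 2 to compound 3 (beyond the scatter), a modest step, which shows that the maximal response at this oxygen does depend on the group there, while compound 1 stays within the scatter of both compound 2 and compound 3. Nothing available explains why vinyl and cyclopropyl part in this way.

On these data alone, all three compounds keep the shared core and vary only at this one oxygen, so how the maximal response would respond to a change elsewhere remains open. Also open, as far as these compounds go, is whether a longer chain such as butyl, or a group carrying an amine or a carboxylic acid, on the same oxygen would stay within the narrow span seen so far or move clearly outside it.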